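The source may report more compounds than this note shows. Statements on the series, on what has been measured and on what is new or still open speak of the compounds shown alone.

Measured so far: compound 1 `COc1ccc2nc(C)cc(OCC(=O)Nc3cc(C)cc(C)c3)c2c1`, 26000 nM; compound 2 `Cc1cc(C)cc(NC(=O)COc2cc(C)nc3ccccc23)c1`, 55000 nM.

In a physicochemical assay for solubility, in phosphate buffer, measured as kinetic solubility, with a stated time of 1 h, at pH 7.4 (a higher number here means a more soluble compound, a lower number a less soluble compound), compound 1 gives 26000 nM, the lowest of the two numbers; in this assay compound 2 gives 55000 nM, and the step of a 2.1-fold higher number from compound 1 to compound 2 (0.33 log units; beyond the scatter) comes from hydrogen in place of methoxy on an aromatic carbon. Compound 3 `COc1ccc2nc(C(F)(F)F)cc(OCC(=O)Nc3cc(C)cc(C)c3)c2c1` differs from compound 1 by trifluoromethyl in place of methyl on an aromatic carbon. Among the compounds with values here, no measured step bears on this exchange; the single measured step concerns the methoxy group only. The expected step of a 1.4-fold lower number from compound 1 to compound 3 (0.16 log units; within the scatter) is therefore set within the scatter, leaning lower. Compound 3 is estimated at 18000 nM, range 6000 nM to 45000 nM.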

Compound 3, solubility: 15000 nM
Compound 3: middle estimate off by 1.2-fold (0.08 log units), on the high side; low and high end bracket the measured number.
By their numbers in this assay, from the lowest: compounds 3 and 1 (each within the scatter of the next); then compound 2.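

At the aromatic carbon next to the ring nitrogen, trifluoromethyl in place of methyl gives, in this assay, a 1.7-fold lower number from compound 1 to compound 3 (0.24 log units; within the scatter). Within the data shown here, this is the first reading at this position: a group of 4 heavy atoms replaces one of 1 heavy atom, and compound 1 and compound 3 cannot be told apart in this read-out. No available evidence bears on this result.

Still open, as far as these compounds go, is whether an amine or a carboxylic acid at this position would give a step beyond the scatter. Also open, from the compounds shown here alone, is whether the same exchange on the core of compound 2 would give a similar step.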